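The source may report more compounds than this note shows. Statements on the series, on what has been measured and on what is new or still open speak of the compounds shown alone.

Measured so far: compound 1 `COc1ccc2nc(NC(=O)CNC(=O)c3nn(-c4ccccc4OC)c(=O)c4ccccc34)sc2c1` and compound 2 `O=C(CNC(=O)c1nn(-c2ccccc2)c(=O)c2ccccc12)Nc1nc2ccc([N+](=O)[O-])cc2s1`.

In an assay on L cells for inhibition of Protein-serine O-palmitoleoyltransferase porcupine (Mus musculus), read by reporter gene assay, with a stated time of 24 h (on this read-out higher numbers stand for an effect only at larger amounts of compound and lower numbers for an effect already at smaller amounts), compound 1 gives 90 nM. In this assay compound 2 gives 240 nM, the higher of the two numbers, and its gap to compound 1 lies beyond the usual scatter. Compound 3 `COc1ccc2nc(NC(=O)CNC(=O)c3nn(-c4ccccc4)c(=O)c4ccccc34)sc2c1` has not been measured. It differs from compound 2 by methoxy in place of nitro on an aromatic carbon. Going by the values given here, no step for this exact change has been measured; a modest move toward a lower number is expected, given that compound 1, which also carries the methoxy, gave 90 nM. For compound 3 the expected step is a 1.8-fold lower number from compound 2 to compound 3 (0.27 log units; within the scatter), giving an estimate of 130 nM with a range from 50 nM to 350 nM.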

Compound 3, half-maximal effective concentration: 210 nM
Compound 3: the middle estimate sits 1.6-fold (0.21 log units) below what was measured; the range from low to high includes it.
By their numbers in this assay, from the lowest: compound 1; then compounds 3 and 2 (each within the scatter of the next).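

In this assay, exchanging 6-nitro-1,3-benzothiazol-2-yl for 6-methoxy-1,3-benzothiazol-2-yl gives a 1.1-fold lower number from compound 2 to compound 3 (0.06 log units; within the scatter), so the two groups cannot be told apart at this position. Going by these compounds alone, the clear gap lies elsewhere: hydrogen in place of methoxy on an aromatic carbon gives a 2.3-fold higher number from compound 1 to compound 3 (0.37 log units; beyond the scatter), the first single change here to go beyond the scatter. Nothing available explains either result. Going by these compounds, whether an amine or a carboxylic acid at the same position would also leave the number unchanged remains open. So does whether the methoxy that compound 1 carries and compound 3 lacks has the same effect alongside nitro.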